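Changing the aryl group on an aromatic nitrogen

The source may hold more compounds than are shown below. What is called first, only, known or untested is meant among the compounds shown, and "the series" means these compounds.

Compound 1 `Cc1c(C(=O)Nc2ccc(Oc3ccnc4[nH]ccc34)cc2)nnn1-c1ccccc1F` and compound 2 `Cc1c(C(=O)Nc2ccc(Oc3ccnc4[nH]ccc34)cc2)nnn1-c1ccc(F)cc1` share one core and differ only in where a fluorine sits on the phenyl ring attached to an aromatic nitrogen. In a functional assay on PC-3 cells (Homo sapiens) for cytotoxicity, read by MTT assay, with a stated time of 72 h (a lower number here means a stronger inhibitor, a higher number a weaker inhibitor), compound 1 gives 3450 nM, and compound 2 gives 3450 nM; the step of no change at the digits printed from compound 1 to compound 2 (within the scatter) lies within the scatter. Compound 3 `Cc1c(C(=O)Nc2ccc(Oc3ccnc4[nH]ccc34)cc2)nnn1-c1ccc(F)c(F)c1` carries a 3,4-difluorophenyl at the same place, and in this assay compound 3 gives "not determined" (no result reported). Compound 4 `Cc1c(C(=O)Nc2ccc(Oc3ccnc4[nH]ccc34)cc2)nnn1-c1ccc(Cl)c(C(F)(F)F)c1` differs from compound 3 by 4-chloro-3-(trifluoromethyl)phenyl in place of 3,4-difluorophenyl on an aromatic nitrogen. Among the compounds with values here, no measured step covers this change; the single measured step shows only that moving one fluorine leaves the number unchanged. Compound 4 is therefore expected to stay near its measured relatives, with an estimate of 3000 nM and a range from 800 nM to 12000 nM.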

Compound 4, half-maximal inhibitory concentration: 10900 nM
Estimate against measurement, compound 4: 3.6-fold (0.56 log units) below; measured number inside the range.
By their numbers in this assay, from the lowest: compounds 1 and 2 (each within the scatter of the next); then compound 4.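

Placing 4-chloro-3-(trifluoromethyl)phenyl on the aromatic nitrogen gives a 3.2-fold higher number from compound 2 to compound 4 (0.50 log units; beyond the scatter) and a 3.2-fold higher number from compound 1 to compound 4 (0.50 log units; beyond the scatter) in this assay. Unlike moving a single fluorine, this change takes the number beyond the scatter, so this position does respond to what its phenyl ring carries, and here the response is a modest move towards weaker inhibition. No measurement shown here accounts for the shift. Going by these compounds, it remains open whether the chlorine, the trifluoromethyl or the two together produce this step, and how an amine or a carboxylic acid on this phenyl ring would compare.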